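The source may hold more compounds than are shown below. What is called first, only, known or untested is meant among the compounds shown, and "the series" means these compounds.

Measured compounds:
compound 1 `O=C(CSc1nnnn1-c1ccccc1)N/N=c1/scc(-c2ccc(Br)cc2)n1-c1ccccc1` — 58.6%
compound 2 `O=C(CSc1ncccn1)N/N=c1/scc(-c2ccc(Br)cc2)n1-c1ccccc1` — 72.1%
compound 3 `Cn1cnnc1SCC(=O)N/N=c1/scc(-c2ccc(C#N)cc2)n1-c1ccccc1` — 62.6%

In a functional assay on C6 cells (Rattus norvegicus) for cytotoxicity, read by MTT assay, with a stated time of 24 h, tested at 12 ug/mL (on this read-out lower numbers stand for a stronger effect and higher numbers for a weaker effect at the one concentration tested), compound 1 stands lowest of the three numbers; compound 3 lies within the scatter of it. Within the data shown here, the only step beyond the scatter is a number 13.5 percentage points higher from compound 1 to compound 2 (beyond the scatter), a change of the group on the sulfur. Compound 4 `O=C(CSc1nnnn1-c1ccccc1)N/N=c1/scc(-c2ccccc2)n1-c1ccccc1` differs from compound 1 in a single place: hydrogen in place of bromo on an aromatic carbon. Among the measured compounds shown here, no measured step bears on this change; compound 3 carries a different group at the same aromatic carbon but also a different group on the sulfur, so its value alone cannot be read as the effect of the bromo. The step of a number 5.4 percentage points higher from compound 1 to compound 4 (within the scatter) is therefore expected to be small, within the scatter or slightly higher. Compound 4 is estimated at 64%, range 50% to 80%.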

Compound 4, a percentage reported as activity, at one concentration (the size of the read-out at that concentration, not a potency): 47.1%
For compound 4 the middle estimate is 16.9 percentage points above the measured one; the whole stated range lies above it.
By their numbers in this assay, from the lowest: compound 4; then compounds 1, 3 and 2 (each within the scatter of the next, the first and the last beyond it).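

In this assay, among these compounds, the change from 4-bromophenyl to phenyl gives the first single-place reading at this aromatic carbon, a number 11.5 percentage points lower from compound 1 to compound 4 (beyond the scatter) and so shows that the position is not silent. The bromo is not needed for the effect at the one concentration tested, and its loss goes with a stronger effect. Nothing on hand accounts for this step.

Still open, as far as these compounds go, is whether a chloro or a methoxy at this carbon would read nearer compound 4 or compound 1. Also open, from the compounds shown here alone, is whether the same change carries over with pyrimidin-2-yl on the sulfur.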